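The source may hold more compounds than are shown below. What is called first, only, known or untested is meant among the compounds shown, and "the series" means these compounds.

Among the measured compounds shown here, compound 1 `COc1ccc(CNCCCNS(=O)(=O)c2cc(C(F)(F)F)cc(C(F)(F)F)c2)cc1OC` is one of three compounds measured in a functional assay on MCF7 cells (Homo sapiens) for inhibition, read by MTT assay, with a stated time of 72 h (on this read-out higher numbers stand for weaker inhibition of growth and lower numbers for stronger inhibition of growth), where compound 1 gives 1900 nM. Compound 2 `O=S(=O)(NCCCNCc1ccc(Br)cc1)c1cc(C(F)(F)F)cc(C(F)(F)F)c1` gives 1900 nM in this assay, and the step of no change at the digits printed from compound 1 to compound 2 (within the scatter). Compound 3 `CC(C)(C)c1ccc(CNCCNS(=O)(=O)c2cc(C(F)(F)F)cc(C(F)(F)F)c2)cc1` gives 13000 nM in this assay; compound 1 and compound 2 together stand at the lowest numbers of the three, and compound 3 lies beyond the scatter above them. Compound 3 differs from compound 1 in more than one place, so its number on its own says nothing about the change at hand.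

Compound 4 `O=S(=O)(NCCCNCc1cccc(Cl)c1)c1cc(C(F)(F)F)cc(C(F)(F)F)c1` has not yet been measured. It differs from compound 1 in one place: 3-chlorophenyl in place of 3,4-dimethoxyphenyl on a saturated chain carbon bound to an amine nitrogen. For the measured compounds named here, the one measured step that bears on this, no change at the digits printed from compound 1 to compound 2 (within the scatter), exchanged the same 3,4-dimethoxyphenyl for a 4-bromophenyl and produced no change beyond the scatter. Compound 4 is therefore expected to stay level with compound 1, with a 1.1-fold higher number from compound 1 to compound 4 (0.02 log units; within the scatter) no larger than the scatter. The estimate for compound 4 in this assay is 2000 nM, expected to fall between 900 nM and 4500 nM.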

Compound 4, concentration for 50% growth inhibition: 2600 nM
The estimate for compound 4 lay 1.3-fold (0.11 log units) below the measured number; the measured number falls inside the stated range.
By their numbers in this assay, from the lowest: compounds 1, 2 and 4 (each within the scatter of the next); then compound 3.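

With a 1.4-fold higher number from compound 1 to compound 4 (0.14 log units; within the scatter) and a 1.4-fold higher number from compound 2 to compound 4 (0.14 log units; within the scatter) in this assay, the 3-chlorophenyl joins the 4-bromophenyl as a second replacement for the 3,4-dimethoxyphenyl on a saturated chain carbon bound to an amine nitrogen, and neither step leaves the scatter. The exchange of compound 1 for compound 4 removes both hydrogen-bond acceptors of the leaving group and reduces its count of heavy atoms, so neither count moves this read-out beyond the scatter for this pair. No measurement among those shown gives a reason for this flat result.

All three groups compared here are substituted phenyl rings, so the result leaves open whether an unsubstituted phenyl, a pyridine ring or a cyclohexyl group would hold the same level. It also leaves open how a carboxylic acid on the ring would read.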